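Cytotoxicity in the oxazole series: pyridinyl for trifluoromethylphenyl

The source may hold more compounds than are shown below. What is called first, only, known or untested is meant among the compounds shown, and "the series" means these compounds.

Two members of the series have been read in an ADME assay on HEK293 cells (Homo sapiens) for cytotoxicity, read by MTT assay, with a stated time of 36 h; a higher number here means a weaker inhibitor, a lower number a stronger inhibitor. Compound 1 `O=C(c1ccc2c(c1)OCCO2)C1CCN(Cc2coc(-c3ccccc3)n2)CC1` carries a plain phenyl on the five-membered ring; in this assay compound 1 returns only a limit, > 150 ug/mL. Compound 2 `O=C(c1ccc2c(c1)OCCO2)C1CCN(Cc2coc(-c3ccc(C(F)(F)F)cc3)n2)CC1` differs by a trifluoromethyl in place of hydrogen on an aromatic carbon; in this assay compound 2 likewise returns only a limit, > 150 ug/mL. The step that the two limits leave unreadable from compound 1 to compound 2 therefore cannot be sized, as both values sit at the limit of > 150 ug/mL in this assay, at which 2 of the 2 values shown sit.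

Compound 3 `O=C(c1ccc2c(c1)OCCO2)C1CCN(Cc2coc(-c3cccnc3)n2)CC1` is not yet measured. Its change from compound 2 is pyridin-3-yl in place of 4-(trifluoromethyl)phenyl on an aromatic carbon. Among the measured compounds shown here, no measured step bears on this change, since the single measured step is itself unreadable. With both known values at the limit, a step that the limit leaves unreadable from compound 2 to compound 3 is expected, and compound 3 is estimated at 200 ug/mL, within 100 ug/mL to 400 ug/mL, most likely reported again as a limit.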

Compound 3, half-maximal inhibitory concentration: > 150 ug/mL
Compound 3 gave a limit, no number (the forecaster's own chance of this, stated with the estimate: 80%); the middle value does not contradict the limit.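

Compound 3, like compound 1 and compound 2, gives only a limit in this assay, so no step among these three compounds can be read: the limit of > 150 ug/mL in this assay, at which 3 of the 3 values shown sit.
The compounds shown leave open whether any group at this place on the five-membered ring gives a number rather than a limit.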